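Working notes: nitro in place of chloro, compound 3

The compounds below may be only part of what the source reports. "The series", "measured", "known", "first", "only" and "open" are said of these compounds alone.

Measured so far in a functional assay on K562 cells (Homo sapiens) for inhibition, read by sulforhodamine B assay, with a stated time of 48 h; a lower number here means a stronger inhibitor of growth, a higher number a weaker inhibitor of growth:
compound 1 `CC1=CC[C@H](C(C)(C)NC(=S)N/N=C/c2ccccc2)CC1` gives 6300 nM
compound 2 `CC1=CC[C@H](C(C)(C)NC(=S)N/N=C/c2cccc(Cl)c2)CC1` gives 5400 nM

Compound 2 sits alongside compound 1 in this assay, the step of a 1.2-fold lower number from compound 1 to compound 2 (0.07 log units; within the scatter) being within the scatter. Compound 3 `CC1=CC[C@H](C(C)(C)NC(=S)N/N=C/c2cccc([N+](=O)[O-])c2)CC1` differs from compound 2 by nitro in place of chloro on an aromatic carbon. Among the compounds with values here, the only measured step that bears on a change at this position, a 1.2-fold lower number from compound 1 to compound 2 (0.07 log units; within the scatter), was within the scatter, so no step beyond the scatter is expected in this assay. Compound 3 is estimated at 5000 nM, with a range from 2000 nM to 13000 nM. The expected step of a 1.1-fold lower number from compound 2 to compound 3 (0.03 log units; within the scatter) is within the scatter.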

Compound 3, concentration for 50% growth inhibition: 45600 nM
Compound 3: middle estimate off by 9.1-fold (0.96 log units), on the low side; measured number outside the range, above it.
By their numbers in this assay, from the lowest: compounds 2 and 1 (each within the scatter of the next); then compound 3.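

In this assay this position on the aromatic ring proves sensitive to the group it carries: nitro in place of chloro gives an 8.4-fold higher number from compound 2 to compound 3 (0.93 log units; beyond the scatter) and nitro in place of hydrogen gives a 7.2-fold higher number from compound 1 to compound 3 (0.86 log units; beyond the scatter) while chloro in place of hydrogen stayed within the scatter. Among these three groups, only nitro separates from the others.

On these data alone, whether an amine or a carboxylic acid at this position would behave like nitro or like chloro remains open. Nothing at hand accounts for the weaker growth inhibition of compound 3.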